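The source may hold more compounds than are shown below. What is called first, only, known or untested is meant among the compounds shown, and "the series" means these compounds.

Measured compounds in an assay on microsomes from liver for inhibition of acyl-CoA desaturase 1 (Rattus norvegicus); a lower number here means a stronger inhibitor, a higher number a weaker inhibitor:
compound 1, `Cc1ccccc1OC1CCN(c2ccc(-n3ccnc3)nn2)CC1`, 39 nM
compound 2, `Cc1ccc(OC2CCN(c3ccc(-n4ccnc4)nn3)CC2)cc1`, 527 nM
compound 3, `FC(F)(F)c1ccccc1OC1CCN(c2ccc(-n3ccnc3)nn2)CC1`, 4 nM

Compound 1 and compound 2 hold the same atoms joined differently; their cores differ by 4-methylphenyl in place of 2-methylphenyl on an oxygen on a saturated carbon, and the step is a 14-fold higher number from compound 1 to compound 2 (1.13 log units; beyond the scatter). Compound 3 comes from compound 1 by trifluoromethyl in place of methyl on an aromatic carbon, giving a 9.8-fold lower number from compound 1 to compound 3 (0.99 log units; beyond the scatter). Compound 4, `FC(F)(F)c1ccc(OC2CCN(c3ccc(-n4ccnc4)nn3)CC2)cc1`, is not yet measured in this assay; it comes from compound 2 by trifluoromethyl in place of methyl on an aromatic carbon. The surroundings differ: in compound 3 the entering group is ortho to a large group, in compound 4 para to a large group, so this is the same kind of change, not the same one. For compound 4 the expected step is an 8.8-fold lower number from compound 2 to compound 4 (0.94 log units; beyond the scatter), set beside a 9.8-fold lower number from compound 1 to compound 3 (0.99 log units; beyond the scatter), on which it rests with added uncertainty. Compound 4 is thus estimated at 60 nM, between 20 nM and 200 nM.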

Compound 4, half-maximal inhibitory concentration: 371 nM
For compound 4 the middle estimate is 6.2-fold (0.79 log units) below the measured one; the measured number lies above the stated range.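

In this assay, trifluoromethyl in place of methyl on an aromatic carbon, para to a large group, gives a 1.4-fold lower number from compound 2 to compound 4 (0.15 log units; within the scatter). This change therefore does not carry from one core to the other with a single size: the same change on two cores in this assay, a 9.8-fold lower number (0.99 log units; beyond the scatter) from compound 1 to compound 3 and a 1.4-fold lower number (0.15 log units; within the scatter) from compound 2 to compound 4, 6.9-fold (0.84 log units) apart, beyond the scatter of two such steps

Two pairs do not show whether the position of the group on the ring alone sets this difference, nor how the change would behave on any further core. The compounds shown leave open whether chlorine, methoxy or a nitrile in place of methyl would depend on the core in the same way.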